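This account rests on a few compounds, and the source may have more. Where it says the series, first, only, none or still open, it means among the compounds named here.

Measured compounds:

Compound 1, `N#CC1CN1C(=O)Nc1ccc(Cl)c(Cl)c1`: in a functional assay on MCF7 cells (Homo sapiens) for inhibition (a lower number here means a stronger inhibitor, a higher number a weaker inhibitor), compound 1 gives 4600 nM.
Compound 2, `CC(C)(C)NC(=O)N1CC1C#N`: in this assay compound 2 gives > 300000 nM, which is a limit of the assay and not a number.
Compound 3, `CCOC(=O)c1ccc(NC(=O)N2CC2C#N)cc1`: in this assay compound 3 gives 2300 nM.

All three compounds share the same core and differ only in the group attached to its urea nitrogen. Compound 3 holds the lowest of the two numbers measured, but compound 1 sits close to it, and the gap between compound 3 and compound 1 lies within the usual scatter, so the two cannot be put in order. Compound 2 stands apart: the limit of > 300000 nM in this assay, at which 1 of the 3 values shown sits.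

Compound 4, `N#CC1CN1C(=O)Nc1ccc(C(F)(F)F)cc1`, has not yet been measured. It differs from compound 3 in one place: trifluoromethyl in place of ethoxycarbonyl on an aromatic carbon. For the measured compounds named here, no step between measured compounds isolates a change of this kind. Compound 1 and compound 3 both carry a substituted aromatic ring and give numbers within the scatter of each other, which suggests that swapping one substituent on that ring for another moves the number little. In this assay the expected step is a 1.3-fold higher number from compound 3 to compound 4 (0.12 log units; within the scatter), not beyond the usual scatter in either direction. Compound 4 is therefore estimated at 3000 nM, with a range from 1000 nM to 10000 nM.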

Compound 4, half-maximal inhibitory concentration: 1500 nM
Compound 4: the middle estimate sits 2.0-fold (0.30 log units) above what was measured; measured number inside the range.
By their numbers in this assay, from the lowest: compounds 4, 3 and 1 (each within the scatter of the next, the first and the last beyond it). At a limit, above all of these: compound 2.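

Swapping ethoxycarbonyl for trifluoromethyl on an aromatic carbon in this assay gives a 1.5-fold lower number from compound 3 to compound 4 (0.19 log units; within the scatter) and is the first step in this set that changes one place only. At this position, para to a group of 8 heavy atoms, ethoxycarbonyl with its 2 hydrogen-bond acceptors and trifluoromethyl with none give numbers within the scatter of each other, so in this pair the acceptors are not needed for a number of this size. No measurement shown here explains why these two different groups read alike.

The compounds shown leave open whether groups of another kind at this place, such as an amine, a carboxylic acid or a longer alkyl chain, would also give numbers within the scatter of compound 3 and compound 4. Also open, on these data alone, is what a plain hydrogen at this place would give, and that comparison would show whether a group is needed there at all.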